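Notes on the amine series: ring change at the chain carbon

The compounds below may be only part of what the source reports. "The series", "measured", "known", "first", "only" and "open" are said of these compounds alone.

Compound 1 `COc1ccc(F)cc1CNCCCNc1ccnc2cc(CC(C)C)ccc12` has been measured in a physicochemical assay for acid dissociation, where compound 1 gives 9.47. Compound 2 `COc1ccc(F)cc1CNCCCNc1ccnc2cc(Cc3ccc(F)cc3)ccc12` in this assay gives 9.47. Going by the values given here, the single measured step, no change at the digits printed from compound 1 to compound 2 (within the scatter), is within the scatter, so compound 1 stands level with compound 2 at the digits printed; compound 2 is its only neighbour and the two cannot be ordered.

Compound 3 `COc1cccc(CNCCCNc2ccnc3cc(CC(C)C)ccc23)c1O` has not yet been measured in this assay. It differs from compound 1 as 2-hydroxy-3-methoxyphenyl in place of 5-fluoro-2-methoxyphenyl on a saturated chain carbon bound to an amine nitrogen. Among the compounds with values here, no measured step bears directly on this change: the one step recorded alters a group on a saturated chain carbon bound to an aromatic carbon, not the carbon bound to the amine nitrogen, and it left the reading unmoved. Within the data shown here, that is the only guide, and it is an indirect one, so the estimate carries a wider range than the measured pair alone would suggest. The expected step is a number 0.12 log units lower from compound 1 to compound 3 (within the scatter), not beyond the scatter. For compound 3 the estimate in this assay is 9.35, expected to fall between 8.75 and 9.95.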

Compound 3, acid dissociation constant: 9.47
Compound 3: the middle estimate sits 0.12 log units below what was measured, within the range that was stated.
By their numbers in this assay, from the lowest: compounds 1, 2 and 3 (each within the scatter of the next).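

Notes on the result: in this assay the place on a saturated chain carbon bound to an amine nitrogen now has a measured step of its own, and 2-hydroxy-3-methoxyphenyl in place of 5-fluoro-2-methoxyphenyl gives no change at the digits printed from compound 1 to compound 3 (within the scatter) at that place. The earlier step, no change at the digits printed from compound 1 to compound 2 (within the scatter), concerned only the saturated chain carbon bound to an aromatic carbon, so compound 1 now has a step within the scatter at each of two different places. This change also swaps a group with 0 hydrogen-bond donors for one with 1 hydrogen-bond donor and removes the fluorine, and the reading still shows no separation, although no measurement here bears on why the reading holds.

From the compounds shown here alone, both groups compared at this place are substituted phenyl rings, so it remains open whether a cyclohexyl ring, or a phenyl ring carrying a carboxylic acid or an amine, would also stay level in this assay at this carbon. Going by these compounds alone, also open is whether a longer chain between the two nitrogens, a different kind of change from either step so far, would leave the reading level.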